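Pentyloxy for Isobutylsulfanyl: Expected Tolerance of Compound 3

The compounds below may be only part of what the source reports. "The series", "measured", "known", "first", "only" and "open" are said of these compounds alone.

Compound 1 `CC(C)CSc1nc(N)nc2c1ncn2/C=C1/CC1(CO)CO` — in an ADME assay on BCBL1 cells (Homo sapiens) for cytotoxicity, with a stated time of 7 days (a lower number here means that less compound is tolerated, a higher number that more compound is tolerated), compound 1 gives > 20000 nM, which is a limit of the measurement rather than a number.
Compound 2 `CC(C)CNc1nc(N)nc2c1ncn2/C=C1/CC1(CO)CO` — in this assay compound 2 gives > 20000 nM, again only a limit.

Compound 1 and compound 2 share one core and differ in a single group, isobutylamino in place of isobutylsulfanyl on an aromatic carbon. Both sit at the same limit (the limit of > 20000 nM in this assay, at which 2 of the 2 values shown sit), so the step that the two limits leave unreadable from compound 1 to compound 2 cannot be read in either direction. Compound 1 therefore stands at the limit of this assay, with no position beyond it that the numbers could fix.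

Compound 3 `CCCCCOc1nc(N)nc2c1ncn2/C=C1/CC1(CO)CO` is not yet measured. It differs from compound 1 in one place: pentyloxy in place of isobutylsulfanyl on an aromatic carbon. Within the data shown here, the only measured step touches the same aromatic carbon but is unreadable, so it offers no size in either direction. With both measured compounds at the limit, no change beyond the scatter is expected for the new side chain.

Compound 3 is expected to give about 30000 nM, within the range 15000 nM to 100000 nM. The estimated step that the limit leaves unreadable from compound 1 to compound 3 is expected to stay within the usual scatter, most likely again ending at the limit.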

Compound 3, half-maximal cytotoxic concentration: > 20000 nM
Compound 3 gave a limit, no number; the forecaster's own chance of this, stated with the estimate: 80%; the middle value lies beyond the limit too.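

Compound 3 gives > 20000 nM in this assay, which is again a limit and not a number, so no step among compound 1, compound 2 and compound 3 can be read: the limit of > 20000 nM in this assay, at which 3 of the 3 values shown sit.

The compounds shown leave open how much of any of the three is tolerated, and whether the three side chains differ at all.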